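Hydrazone series on Ehrlich cells: benzofuran for phenyl

A few compounds are considered here, and "the series" means these few. Any claim that something is new, unique, unknown or untested is made for them only; others in the source may bear on it.

Measured so far:
compound 1 `C/C(=N\N=C1\N=C(c2ccccc2)CS1)c1nc(-c2ccccc2)[nH]c1C` — 19.5 ug/mL
compound 2 `C/C(=N\N=C1\NC(=O)/C(=C/c2ccc(F)cc2)S1)c1nc(-c2ccccc2)[nH]c1C` — 14.5 ug/mL
compound 3 `C/C(=N/NC(=O)c1cc2ccc(O)cc2oc1=N)c1nc(-c2ccccc2)[nH]c1C` — 151 ug/mL

Three compounds of the series have a number in a functional assay on Ehrlich cells (Mus musculus) for cytotoxicity, read by trypan blue exclusion and cell counting, with a stated time of 2 h; a lower number here means a stronger inhibitor, a higher number a weaker inhibitor. Compound 1 gives 19.5 ug/mL, the second highest of the three numbers. Its nearest neighbour is compound 2 at 14.5 ug/mL, a gap that lies within the usual scatter of this assay, so the two are not told apart. Its furthest neighbour is compound 3 at 151 ug/mL, a gap beyond the scatter; compound 3 carries a different arrangement at the hydrazone end, so nothing links it to compound 1 in a single step.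

Compound 4 `C/C(=N\N=C1\N=C(c2cc3ccccc3o2)CS1)c1nc(-c2ccccc2)[nH]c1C` has not yet been measured. Set against compound 1 it differs in one place: 1-benzofuran-2-yl in place of phenyl on a carbon with a double bond to nitrogen. Among the measured compounds shown here, no pair of measured compounds differs in this way, so there is no calibrating step for the change. The shared core of compound 1 is kept, and only the group on a carbon with a double bond to nitrogen is exchanged. On this basis the expected step of a 1.1-fold lower number from compound 1 to compound 4 (0.06 log units; within the scatter) is small, with no clear direction and none beyond the scatter. Compound 4 is estimated at 17 ug/mL, with a range from 7 ug/mL to 40 ug/mL.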

Compound 4, half-maximal inhibitory concentration: 21.5 ug/mL
Compound 4: middle estimate off by 1.3-fold (0.10 log units), on the low side, and the stated range covers the measured number.
By their numbers in this assay, from the lowest: compounds 2, 1 and 4 (each within the scatter of the next); then compound 3.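

In this assay the exchange of phenyl for 1-benzofuran-2-yl gives a 1.1-fold higher number from compound 1 to compound 4 (0.04 log units; within the scatter) and this is the only single-place step among the compounds shown. It lies within the scatter, so on a carbon with a double bond to nitrogen of the five-membered non-aromatic ring, a group of 9 heavy atoms with a second aromatic ring and a hydrogen-bond acceptor stands in place of one with 6 heavy atoms and neither, without a difference that this assay can tell apart. No measurement of any property of these compounds bears on this step.

From the compounds shown here alone, whether this place accepts only aromatic groups stays open, and an amine, a carboxylic acid or a longer chain on the same carbon would address that question. Among the compounds shown here, the number for compound 3 also remains unassigned to any single change, as no one-place step links it to compound 1 or compound 4.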